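The source may report more compounds than this note shows. Statements on the series, on what has been measured and on what is new or still open speak of the compounds shown alone.

Of the compounds shown here, two of a shared core have been measured in an assay on a cell-free system (plasma) for inhibition of Dipeptidyl peptidase 4 (Rattus norvegicus), read by fluorescence, with a stated time of 60 min; on this read-out higher numbers stand for weaker inhibition and lower numbers for stronger inhibition. Compound 1, `O=C([C@@H]1C[C@H](N2CCN(c3nnnn3C3CCCCC3)CC2)CN1)N1CCSC1`, gives 3.1 nM. Compound 2, `Cc1cc(N2CCN([C@@H]3CN[C@H](C(=O)N4CCSC4)C3)CC2)n(-c2cccc(F)c2)n1`, gives 0.49 nM. Of the two numbers, compound 2 has the lower one, and the gap to compound 1 lies beyond the scatter of repeated measurements, so compound 2 is the stronger inhibitor of the pair.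

Compound 3, `Cc1cc(N2CCN([C@@H]3CN[C@H](C(=O)N4CCSC4)C3)CC2)n(-c2cccnc2)n1`, differs from compound 2 in one place: pyridin-3-yl in place of 3-fluorophenyl on an aromatic nitrogen. Going by the values given here, no pair of measured compounds shows what such an exchange does on this core, so the expectation rests on compound 2 alone. The step is expected to be small, near the scatter, with at most a slight move toward a higher number. For compound 3 the expected value in this assay is 0.8 nM, within a range of 0.3 nM to 2.5 nM. The step from compound 2 is thus estimated as a 1.6-fold higher number from compound 2 to compound 3 (0.21 log units; within the scatter).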

Compound 3, half-maximal inhibitory concentration: 0.77 nM
For compound 3 the middle estimate is 1.0-fold (0.02 log units) above the measured one, and the stated range covers the measured number.
By their numbers in this assay, from the lowest: compounds 2 and 3 (each within the scatter of the next); then compound 1.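

In this assay, going by these compounds alone, pyridin-3-yl in place of 3-fluorophenyl on the aromatic nitrogen gives a 1.6-fold higher number from compound 2 to compound 3 (0.20 log units; within the scatter) and so offers the first readable exchange at this position. The ring that leaves is carbon only and carries fluorine, while the ring that enters holds one nitrogen and adds one hydrogen-bond acceptor, yet this assay does not separate the two compounds. Nothing measured here speaks to the reason for this result.

Still open, from the compounds shown here alone, is what a carboxylic acid or an amine on this aromatic ring would do, or a plain alkyl chain in place of the ring. The compounds shown also cannot tell whether the same exchange would give a similar result with the methyl group on the five-membered ring replaced by an ethyl group.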